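The source may report more compounds than this note shows. Statements on the series, on what has been measured and on what is new or still open speak of the compounds shown alone.

In a functional assay on PC-3 cells (Homo sapiens) for cytotoxicity, read by MTT assay, with a stated time of 48 h (on this read-out higher numbers stand for weaker inhibition and lower numbers for stronger inhibition), compound 1 `COc1ccccc1C1CC(C)=NN1C(=O)C[N+]1(C)CCCC1` gives 11200 nM, and compound 2 `O=C(c1ccccc1Cl)N1N=C(c2cc3ccccc3oc2=O)CC1c1ccccc1` gives 6370 nM; the two numbers lie within the usual scatter of each other, so neither can be set apart. Compound 3 `CC1CCCCN1CC(=O)N1N=C(c2cc3ccccc3oc2=O)CC1c1ccccc1` differs from compound 2 by (2-methylpiperidin-1-yl)methyl in place of 2-chlorophenyl on a carbonyl carbon. Among the measured compounds shown here, with no measured pair showing this kind of change, compound 3 is expected to stay close to compound 2, with a step of a 1.4-fold higher number from compound 2 to compound 3 (0.15 log units; within the scatter) that is not beyond the scatter. The expected value for compound 3 in this assay is 9000 nM, within the range 3000 nM to 30000 nM.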

Compound 3, half-maximal inhibitory concentration: 36300 nM
Compound 3: middle estimate off by 4.0-fold (0.61 log units), on the low side; the measured number lies above the stated range.
By their numbers in this assay, from the lowest: compounds 2 and 1 (each within the scatter of the next); then compound 3.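

The swap of 2-chlorophenyl for (2-methylpiperidin-1-yl)methyl on a carbonyl carbon gives a 5.7-fold higher number from compound 2 to compound 3 (0.76 log units; beyond the scatter) in this assay and so shows that this position is not indifferent to the group it carries. Within this single pair, the 2-chlorophenyl group holds the lower number. No measurement at hand accounts for the step.

The compounds shown leave open whether the step follows the ring, the added methylene or the methyl on the piperidine. A benzyl group or an unsubstituted piperidin-1-ylmethyl group at this position would begin to separate these.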